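Butylamino in place of butoxy on the shared core

A few compounds are considered here, and "the series" means these few. Any claim that something is new, unique, unknown or untested is made for them only; others in the source may bear on it.

In an ADME assay on BCBL1 cells (Homo sapiens) for cytotoxicity, with a stated time of 7 days (a lower number here means that less compound is tolerated, a higher number that more compound is tolerated), compound 3 `CCCCOc1nc(N)nc2c1ncn2/C=C1/CC1(CO)CO` gives only a limit (> 20000 nM). Compound 2 `Nc1nc(NC2CCCCC2)c2ncn(/C=C3/CC3(CO)CO)c2n1` also gives only a limit (> 20000 nM). That is the limit of > 20000 nM in this assay, at which 2 of the 3 values shown sit, and no number. Compound 1 `Nc1nc(NC2CCCC2)c2ncn(/C=C3/CC3(CO)CO)c2n1` gives a true number (71700 nM). Compound 4 `CCCCNc1nc(N)nc2c1ncn2/C=C1/CC1(CO)CO` differs from compound 3 as follows: butylamino in place of butoxy on an aromatic carbon. Among the compounds with values here, the steps that bear on this change are a step that the limit leaves unreadable from compound 1 to compound 3 and a step that the two limits leave unreadable from compound 2 to compound 3 along with a step that the limit leaves unreadable from compound 1 to compound 2 and none has a readable size. Within the data shown here, no firm size or direction can therefore be expected, and the only numeric guide is compound 1 (71700 nM), which also carries an amino link. The expected step is a step that the limit leaves unreadable from compound 3 to compound 4 and it remains uncertain. The estimate for compound 4 is 40000 nM with an expected range from 12000 nM to 120000 nM as its ends.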

Compound 4, half-maximal cytotoxic concentration: > 20000 nM
Compound 4 gave a limit, no number; the forecaster's own chance of this, stated with the estimate: 55%; the middle value lies beyond the limit too.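

No step to compound 4 from compound 1, compound 2 or compound 3 can be read, because compound 4 gives only a limit: the limit of > 20000 nM in this assay, at which 3 of the 4 values shown sit.

The compounds shown leave open whether butylamino and butoxy on the shared core differ at all in this assay.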